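The source may hold more compounds than are shown below. What is called first, only, known or untested is meant among the compounds shown, and "the series" means these compounds.

In a functional assay on DU-145 cells (Homo sapiens) for cytotoxicity, read by WST assay, with a stated time of 48 h (on this read-out higher numbers stand for weaker inhibition and lower numbers for stronger inhibition), compound 1 `COc1ccccc1N1CCN(CCCNC(=O)CCCc2c[nH]c3ccccc23)CC1` reads > 100000 nM, which is a limit of the assay and not a number. For the measured compounds named here, compound 2 `COc1ccccc1N1CCN(CCCNC(=O)c2cc3ccc(Br)cc3[nH]2)CC1` gives 39300 nM, the only actual number so far. Compound 3 `COc1ccccc1N1CCN(CCCNC(=O)c2cc3cc(Cl)ccc3[nH]2)CC1` changes one place of compound 2: 5-chloro-1H-indol-2-yl in place of 6-bromo-1H-indol-2-yl on a carbonyl carbon. Here, 5-chloro-1H-indol-2-yl stands in place of 6-bromo-1H-indol-2-yl on a carbonyl carbon. Going by the values given here, no measured step offers a guide, so no shift beyond the scatter is expected in this assay, and the estimated 1.0-fold higher number from compound 2 to compound 3 (0.01 log units; within the scatter) has no favoured direction. Compound 3 is expected at 40000 nM, with an estimated range of 15000 nM to 100000 nM.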

Compound 3, half-maximal inhibitory concentration: 47000 nM
The estimate for compound 3 lay 1.2-fold (0.07 log units) below the measured number; measured number inside the range.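

The step on this position, a 1.2-fold higher number from compound 2 to compound 3 (0.08 log units; within the scatter), shows that in this assay 5-chloro-1H-indol-2-yl can stand in place of 6-bromo-1H-indol-2-yl on a carbonyl carbon with no change beyond the scatter. The halogen and its place differ together, so this step cannot separate the two. Compound 1 remains a limit of the assay and not a number, so little room lies above these readings: the limit of > 100000 nM in this assay, at which 1 of the 3 values shown sits.

Left open is how an unsubstituted 1H-indol-2-yl, or one carrying an amine or a carboxylic acid, would read on this carbonyl carbon.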